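The source may report more compounds than this note shows. Statements on the series, on what has been measured and on what is new or still open speak of the compounds shown alone.

Three sulfonamides on a benzoxazole-type shared core have been tested in an assay on cells for inhibition of HSP60/HSP10 (Homo sapiens), with a stated time of 60 min; on this read-out higher numbers stand for weaker inhibition and lower numbers for stronger inhibition. Compound 1 `O=S(=O)(Nc1ccc2oc(-c3ccc(NS(=O)(=O)c4cccc5nonc45)cc3)nc2c1)c1ccc(Cl)s1` carries two sulfonamide arms and gives 13000 nM in this assay. Compound 2 `O=S(=O)(Nc1ccc(-c2nc3ccccc3o2)cc1)c1cccc(F)c1`, with a single 3-fluorophenyl sulfonamide, gives 71000 nM. Compound 3 `Cc1ccc(S(=O)(=O)Nc2ccc(-c3nc4ccccc4o3)cc2)cc1` reaches only the limit of this assay, > 100000 nM, so no number is known for it. The step of an at least 1.4-fold higher number from compound 2 to compound 3 (0.14 log units; that floor lies within the scatter) is therefore a floor, and compound 3 stands at the weak end of what is shown, resolved no further than the limit of > 100000 nM in this assay, at which 1 of the 3 values shown sits.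

Compound 4 `O=S(=O)(Nc1ccc(-c2nc3ccccc3o2)cc1)c1ccc(Cl)s1` differs from compound 3 by 5-chlorothiophen-2-yl in place of 4-methylphenyl on a sulfonyl sulfur. Going by the values given here, the only measured step at this position is the one from compound 2 to compound 3, a floor that lies within the scatter, so it gives little guidance on size. Among the compounds with values here, compound 1, which carries the same 5-chlorothiophen-2-yl on a sulfonyl sulfur within a larger structure, sits at its own value of 13000 nM, but no step links it to compound 4. Compound 4 is therefore expected to move from the limit of compound 3 by about an at least 2.5-fold lower number from compound 3 to compound 4 (0.39 log units; beyond the scatter) toward stronger inhibition in this assay. The estimate for compound 4 in this assay is 40000 nM, within a range from 12000 nM to 130000 nM.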

Compound 4, half-maximal inhibitory concentration: 31000 nM
Compound 4: the middle estimate sits 1.3-fold (0.11 log units) above what was measured, within the range that was stated.
By their numbers in this assay, from the lowest: compound 1; then compound 4; then compound 2. At a limit, above all of these: compound 3.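

Among the groups on the sulfonyl sulfur, 5-chlorothiophen-2-yl gives the first step at this position in this assay with a full size and beyond the scatter, a 2.3-fold lower number from compound 2 to compound 4 (0.36 log units; beyond the scatter) and so the position is shown to respond to this change. As far as these compounds go, in place of 4-methylphenyl the same group gives an at least 3.2-fold lower number from compound 3 to compound 4 (0.50 log units; beyond the scatter) and this is a floor, so its true size stays unknown. Compound 3 stands at a limit and not at a number: the limit of > 100000 nM in this assay, at which 1 of the 4 values shown sits.

The compounds shown leave open whether the chlorine or the five-membered ring with its sulfur carries the step, as neither an unsubstituted thiophen-2-yl nor a 4-chlorophenyl stands among them. From the compounds shown here alone, how an amine or a carboxylic acid on the ring at this position would read also remains open.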